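The compounds below may be only part of what the source reports. "The series", "measured", "known", "first", "only" and "open" are said of these compounds alone.

Of the compounds shown here, three have so far been measured in a functional assay on the whole organism with Rattus norvegicus as the target; on this read-out higher numbers stand for an effect only at larger amounts of compound and lower numbers for an effect already at smaller amounts. Compound 1 `CC1CCC(=NNc2ccccc2C(=O)O)c2ncc(C(=O)NO)c(=O)n21` gives > 100 umol/kg in this assay, which is a limit of the assay and not a number. Compound 2 `CC1CCC(=NNc2ccc(Cl)c(Cl)c2)c2ncc(C(=O)O)c(=O)n21` likewise stops at the limit of > 100 umol/kg in this assay. Compound 3 `CC1CCC(=NNc2cc(C(F)(F)F)cc(C(F)(F)F)c2)c2ncc(C(=O)O)c(=O)n21` also stops at the limit of > 100 umol/kg. Among the measured compounds shown here, compound 2 therefore stands at the limit of > 100 umol/kg in this assay, at which 3 of the 3 values shown sit, and no step between measured compounds can be read off. Compound 4 `CNN=C1CCC(C)n2c1ncc(C(=O)O)c2=O` differs from compound 2 by methyl in place of 3,4-dichlorophenyl on an amine nitrogen. With every measured value a limit, no direction can be taken from the data. Compound 4 is expected at 150 umol/kg, with a range from 30 umol/kg to 1000 umol/kg. On this estimate a step that the limit leaves unreadable from compound 2 to compound 4 is expected to stay within the scatter.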

Compound 4, dose for 50% inhibition: > 100 umol/kg
Compound 4: no number, only a limit; the forecaster's own chance of this, stated with the estimate: 75%; the middle value is on the limit's open side.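

Among the compounds shown here, compound 4, like compound 2, gives only a limit of the assay and not a number, so no step between the two can be read: the limit of > 100 umol/kg in this assay, at which 4 of the 4 values shown sit. The compounds shown leave open at what dose any of them would reach the half-maximal inhibition.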